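The source may hold more compounds than are shown below. What is called first, only, known or untested is meant among the compounds shown, and "the series" means these compounds.

Three compounds share an enone linker between two aromatic rings. Compound 1 `C=C(Br)C(=O)Nc1ccc(C(=O)/C=C/c2cccc(OC)c2)cc1` gives 1800 nM in an ADME assay on CCRF-CEM cells (Homo sapiens) for antiproliferative activity, with a stated time of 48 h (on this read-out lower numbers stand for stronger inhibition and higher numbers for weaker inhibition), and compound 2 `C=C(Br)C(=O)Nc1ccc(C(=O)/C=C/c2cc(OC)cc(OC)c2)cc1` gives 2200 nM in the same read-out. The two differ by one change, (methoxy in place of hydrogen on an aromatic carbon), and the step of a 1.2-fold higher number from compound 1 to compound 2 (0.09 log units; within the scatter) stays within the usual scatter. Compound 3 `Nc1ccc(C(=O)/C=C/c2ccccc2)cc1` carries a free amine where compounds 1 and 2 carry the bromoacrylamide; how the two cores differ is not broken down here. In this assay compound 3 gives 8500 nM, the highest of the three numbers, and its gap to both compound 1 and compound 2 lies beyond the scatter.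

Compound 4 `COc1cccc(/C=C/C(=O)c2ccc(N)cc2)c1` is not yet measured. It differs from compound 3 by methoxy in place of hydrogen on an aromatic carbon, the same kind of change as that from compound 1 to compound 2. The two places are not identical in every word: in compound 2 the entering methoxy sits meta to a large group and also meta to a methoxy group, whereas in compound 4 it sits meta to a large group on a ring that carries no second methoxy.

On the core of compound 1 this kind of change moved the number by a 1.2-fold higher number from compound 1 to compound 2 (0.09 log units; within the scatter); the step from compound 3 to compound 4 is therefore expected to be of similar size, a 1.1-fold higher number from compound 3 to compound 4 (0.05 log units; within the scatter), since no other pair among these compounds speaks against it. Compound 4 is thus estimated at 9500 nM, with a range from 4500 nM to 20000 nM.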

Compound 4, half-maximal inhibitory concentration: 23000 nM
For compound 4 the middle estimate is 2.4-fold (0.38 log units) below the measured one; the measured number lies above the stated range.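

In this assay, methoxy in place of hydrogen gives a 2.7-fold higher number from compound 3 to compound 4 (0.43 log units; beyond the scatter) on the free-amine core, whereas on the bromoacrylamide core it gave a 1.2-fold higher number from compound 1 to compound 2 (0.09 log units; within the scatter), yet the gap between the two steps does not show that the cores respond differently: the same change on two cores in this assay, a 1.2-fold higher number (0.09 log units; within the scatter) from compound 1 to compound 2 and a 2.7-fold higher number (0.43 log units; beyond the scatter) from compound 3 to compound 4, 2.2-fold (0.35 log units) apart, within the scatter of two such steps. Among these compounds, this comparison leaves the change compatible with carrying over from one core to the other, but it does not establish a shared size, since each core supplies a single pair, only one of the two steps lies beyond the scatter, and the methoxy entering compound 2 joins a ring that already carries a methoxy, which is not so for compound 4. The step at the nitrogen, a 13-fold higher number from compound 1 to compound 4 (1.11 log units; beyond the scatter), is large and exceeds both methoxy steps, so on these compounds the group on that nitrogen counts for more than the methoxy change.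

The compounds shown leave open whether the bromine or the whole acyl group accounts for that step, which an acetyl or a plain acryloyl on the nitrogen would address. They also leave open whether a second methoxy on the free-amine core, or a hydroxy or a chlorine in place of the methoxy, would follow the same course.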